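Compound 3 to compound 4: methyl replaced by hydrogen

This account rests on a few compounds, and the source may have more. Where it says the series, first, only, none or still open, it means among the compounds named here.

In a functional assay on MCF7 cells (Homo sapiens) for antiproliferative activity, read by MTT assay (on this read-out lower numbers stand for stronger inhibition and higher numbers for weaker inhibition), compound 3 (`CCCCCCCCCCCCCCCc1cc(=O)c2c(O)c(C)c(O)c(C)c2o1`) gives only a limit (> 67200 nM). The change to compound 4 (`CCCCCCCCCCCCCCCc1cc(=O)c2c(O)cc(O)c(C)c2o1`) is hydrogen in place of methyl on an aromatic carbon. Compound 1 (`CCCC/C=C\CCCCCCCCCc1cc(=O)c2c(O)cc(O)c(C)c2o1`) gives 17500 nM in this assay and compound 2 (`CCCCC/C=C\C/C=C\CCCCCCCc1cc(=O)c2c(O)cc(O)c(C)c2o1`) gives 17500 nM there, both with hydrogen on that carbon and with unsaturated chains. Within the data shown here, the one measured step (no change at the digits printed from compound 1 to compound 2 (within the scatter)) lies within the scatter and concerns the chain only, so no measured step tests the methyl directly. Compound 4 shares that hydrogen with compound 1 (17500 nM), so a number nearer that value is expected, though its saturated chain leaves the size open. The expected step (an at least 2.2-fold lower number from compound 3 to compound 4 (0.35 log units; beyond the scatter)) is towards stronger inhibition, and a further limit remains possible. Compound 4 is estimated at 30000 nM (range 12000 nM to 67000 nM).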

Compound 4, half-maximal inhibitory concentration: 17500 nM
Compound 4: the middle estimate sits 1.7-fold (0.23 log units) above what was measured; the measured number falls inside the stated range.
By their numbers in this assay, from the lowest: compounds 1, 2 and 4 (each within the scatter of the next). At a limit, above all of these: compound 3.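

In this assay, this aromatic carbon now has a direct test: with hydrogen in place of methyl, the data show an at least 3.8-fold lower number from compound 3 to compound 4 (0.58 log units; beyond the scatter). With hydrogen on that carbon, the saturated chain and the two unsaturated chains do not separate, with no change at the digits printed from compound 2 to compound 4 (within the scatter) and no change at the digits printed from compound 1 to compound 4 (within the scatter). The size of the methyl step stays open on one side, since compound 3 is only a limit: the limit of > 67200 nM in this assay, at which 1 of the 4 values shown sits.

Going by these compounds, it remains open whether a larger group at this carbon, such as ethyl, an amine or a carboxylic acid, would shift the number. On these data alone, the effect of a much shorter chain also remains open.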